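The source may report more compounds than this note shows. Statements on the series, on what has been measured and on what is new or still open speak of the compounds shown alone.

Compound 2 `CCCC1CCC(OC(=O)N[C@@H](CC(C)C)C(=O)N[C@H](C=O)C[C@@H]2CCNC2=O)CC1` and compound 1 `CCCCC1CCC(OC(=O)N[C@@H](CC(C)C)C(=O)N[C@H](C=O)C[C@@H]2CCNC2=O)CC1` share one core and differ only in the chain carried on the saturated ring. In a toxicity assay on L929 cells (Mus musculus) for cytotoxicity (on this read-out higher numbers stand for lower toxicity in this test and lower numbers for higher toxicity in this test), compound 1 gives 63300 nM. For compound 2 this assay reports only a limit, > 100000 nM, which is a bound of the measurement rather than a number, as the limit of > 100000 nM in this assay, at which 1 of the 2 values shown sits, records. Among the compounds with values here, the single measured step, an at least 1.5-fold higher number from compound 1 to compound 2 (0.19 log units; that floor lies within the scatter), is therefore itself only a floor, and that floor lies within the scatter. Compound 3 `CC(C)C[C@H](NC(=O)OC1CCC(F)(F)CC1)C(=O)N[C@H](C=O)C[C@@H]1CCNC1=O` has not yet been measured in this assay. It differs from compound 2 by 4,4-difluorocyclohexyl in place of 4-propylcyclohexyl on an oxygen next to a carbonyl group. That change removes the chain altogether and brings fluorine onto the ring, so the measured step bears on it only loosely: taking methyl away from the chain between compound 1 and compound 2 gave a step whose floor sits within the scatter. No step beyond the scatter is expected here, and the reading for compound 3 is expected to sit close to the limit. The estimate for compound 3 in this assay is 100000 nM, with an expected range from 40000 nM to 300000 nM, corresponding to an expected step of a number no higher from compound 2 to compound 3 (the limit leaves the size open).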

Compound 3, half-maximal cytotoxic concentration: > 100000 nM
Compound 3 was reported as a limit (the forecaster's own chance of this, stated with the estimate: 60%); the middle value sits exactly at the limit.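

Compound 3 joins compound 2 at the same limit of the measurement, so two different groups on an oxygen next to a carbonyl group now reach the top of this read-out, one with a propyl chain and one with fluorine on the ring and no chain: the limit of > 100000 nM in this assay, at which 2 of the 3 values shown sit.

Compared with compound 1, the only one of the three with a measured number in this assay, the change gives an at least 1.5-fold higher number from compound 1 to compound 3 (0.19 log units; that floor lies within the scatter), so what is known is a floor and not a true size. The step from compound 2 to compound 3 cannot be read, and the 4-propylcyclohexyl and 4,4-difluorocyclohexyl groups cannot be put in any order in this test.

The compounds shown leave open how far the real values of compound 2 and compound 3 lie past the limit, so the size of any difference from compound 1 remains unknown. Also open, from the compounds shown here alone, is whether a 4-hexylcyclohexyl group, with its longer chain, or a cyclohexyl ring carrying an amine would bring the number clearly down from the limit.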